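The source may hold more compounds than are shown below. What is called first, only, known or untested is meant among the compounds shown, and "the series" means these compounds.

Compound 1 `NCCCCN(C[C@H]1Cc2ncccc2CN1)[C@H]1CCCc2cccnc21`: 86%
Compound 2 `CN(CCCCN(C[C@H]1Cc2ncccc2CN1)[C@H]1CCCc2cccnc21)C1CCOCC1`: 51%

Within the data shown here, in an ADME assay on microsomes from liver (Mus musculus) for metabolic stability, using NADPH, with a stated time of 10 min (on this read-out lower numbers stand for a less stable compound and higher numbers for a more stable compound), compound 2 gives 51%, the lower of the two numbers measured so far, and compound 1 gives 86%. Compound 3 `c1cnc2c(c1)CN[C@@H](CN(CCCCN(C1COC1)C1COC1)[C@H]1CCCc3cccnc31)C2` has not yet been measured. It differs from compound 2 as follows: a group of 9 heavy atoms (6 carbon, 1 nitrogen, 2 oxygen; 2 four-membered non-aromatic rings with 1 hetero atom each) in place of a group of 8 heavy atoms (6 carbon, 1 nitrogen, 1 oxygen; one six-membered non-aromatic ring with 1 hetero atom), on a saturated chain carbon, four bonds along the chain from an amine nitrogen. Among the measured compounds shown here, only one measured step bears on this change, as it falls at the same place on the chain: a number 35 percentage points lower from compound 1 to compound 2 (beyond the scatter). That large step replaced an amino group, which has hydrogen-bond donors, with methyl(oxan-4-yl)amino. The new change is of another kind, since the group that leaves and the group that enters both have no hydrogen-bond donors and no net charge. The data do not show which way such a swap moves the number, so no step beyond the scatter is expected in this assay, and the estimate stays close to the measured number of compound 2, which is 51%. The expected change is a number 4 percentage points higher from compound 2 to compound 3 (within the scatter). For compound 3, the estimated value is 55%, with an expected range from 33% to 77%.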

Compound 3, percent of the compound remaining: 33%
Compound 3: the middle estimate sits 22 percentage points above what was measured, within the range that was stated.
By their numbers in this assay, from the lowest: compound 3; then compound 2; then compound 1.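

In this assay, the group with two four-membered rings in place of methyl(oxan-4-yl)amino gives a number 18 percentage points lower from compound 2 to compound 3 (beyond the scatter), so the number at this place on the chain still moves when neither the group that leaves nor the group that enters has a hydrogen-bond donor or a net charge. Set against the amino group, the same group gives a number 53 percentage points lower from compound 1 to compound 3 (beyond the scatter), which goes further than the earlier a number 35 percentage points lower from compound 1 to compound 2 (beyond the scatter), and among these three compounds the amino group of compound 1 goes with the highest number. No measurement at hand accounts for the difference between the two groups without donors.

The swap changes ring size and the number of rings at once, and the compounds shown cannot separate the two, so it stays open which of them goes with the lower number. Methyl(oxetan-3-yl)amino, which keeps the methyl of compound 2 and carries a single four-membered ring, would bear on that question, and dimethylamino would show what the number does with no ring at all on this nitrogen.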